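This account rests on a few compounds, and the source may have more. Where it says the series, first, only, none or still open, it means among the compounds named here.

Compound 1 `CCOC(=O)c1cccc(-c2ccc(OCC)c(N)c2)c1` gives 140000 nM in an assay on COS-7 cells for inhibition of patatin-like phospholipase domain-containing protein 2 (Mus musculus); on this read-out lower numbers stand for stronger inhibition and higher numbers for weaker inhibition.
Compound 2 `CCOc1ccc(-c2cccc(C)c2)cc1` gives 70000 nM in this assay.

Compound 2 carries the lower of the two numbers, but compound 1 lies within the usual scatter of it, so the two cannot be told apart. Compound 3 `CCOc1ccc(-c2cccc(C(=O)OCCOC)c2)cc1` arises from compound 2 through the change ((2-methoxyethoxy)carbonyl in place of methyl on an aromatic carbon). For the measured compounds named here, no measured pair shows this exchange, and compound 1, with its own substituents, offers no firm guide. In this assay no step beyond the scatter is expected in either direction. Compound 3 is therefore estimated at 80000 nM, within 25000 nM to 250000 nM. That expectation amounts to a step of a 1.1-fold higher number from compound 2 to compound 3 (0.06 log units; within the scatter).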

Compound 3, half-maximal inhibitory concentration: 70000 nM
Beside the measured number, compound 3's estimate is 1.1-fold (0.06 log units) above it, within the range that was stated.
By their numbers in this assay, from the lowest: compounds 2, 3 and 1 (each within the scatter of the next).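

In this assay, the exchange of methyl for (2-methoxyethoxy)carbonyl on this aromatic carbon gives no change at the digits printed from compound 2 to compound 3 (within the scatter) and thus leaves the read-out unmoved. This position therefore accepts a far larger chain carrying hydrogen-bond acceptors, where methyl has none, with no step beyond the scatter. No measurement shown here accounts for this result. Still open, going by these compounds, is whether a carboxylic acid or an amine on this aromatic carbon would give a step beyond the scatter. The same holds for a longer chain in this place.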